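Replacing isopropyl with a benzyl ester side chain

The source may report more compounds than this note shows. Statements on the series, on what has been measured and on what is new or still open speak of the compounds shown alone.

Three measured compounds share one core and differ only in the group on a saturated chain carbon bound to an amide-type nitrogen and a carbonyl carbon. In a functional assay on HeLa cells (Homo sapiens) for antiproliferative activity, read by MTT assay, with a stated time of 48 h (a higher number here means a weaker inhibitor, a lower number a stronger inhibitor), compound 1 `C[C@H](NC(=O)c1cc2ccccc2cn1)C(=O)OCc1ccccc1` gives 154 nM. Compound 2 `CC(C)[C@H](NC(=O)c1cc2ccccc2cn1)C(=O)OCc1ccccc1` gives 118 nM in this assay, and compound 3 `NCCCC[C@H](NC(=O)c1cc2ccccc2cn1)C(=O)OCc1ccccc1` gives 196 nM. Compound 2 has the lowest of the three numbers, yet every step between them stays within the scatter: a 1.3-fold lower number from compound 1 to compound 2 (0.12 log units; within the scatter), a 1.3-fold higher number from compound 1 to compound 3 (0.10 log units; within the scatter) and a 1.7-fold higher number from compound 2 to compound 3 (0.22 log units; within the scatter). Compound 4 `O=C(CC[C@H](NC(=O)c1cc2ccccc2cn1)C(=O)OCc1ccccc1)OCc1ccccc1` carries 2-(benzyloxycarbonyl)ethyl in place of isopropyl on a saturated chain carbon bound to an amide-type nitrogen and a carbonyl carbon. Within the data shown here, no measured step introduces a group of this kind; the three steps bear on it only by showing that exchanging methyl, isopropyl and 4-aminobutyl at this same carbon left the numbers within the scatter. On that basis the step from compound 2 to compound 4 is expected to be a 1.4-fold higher number from compound 2 to compound 4 (0.13 log units; within the scatter), with a wide range because the new group is far larger than any tested. Compound 4 is estimated at 160 nM in this assay, between 60 nM and 450 nM.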

Compound 4, half-maximal inhibitory concentration: 214 nM
Compound 4: middle estimate off by 1.3-fold (0.13 log units), on the low side; the range from low to high includes it.
By their numbers in this assay, from the lowest: compounds 2, 1, 3 and 4 (each within the scatter of the next).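

In this assay there is a 1.8-fold higher number from compound 2 to compound 4 (0.26 log units; within the scatter) and a 1.4-fold higher number from compound 1 to compound 4 (0.14 log units; within the scatter) and a 1.1-fold higher number from compound 3 to compound 4 (0.04 log units; within the scatter) on installing 2-(benzyloxycarbonyl)ethyl, a group of 12 heavy atoms with one six-membered aromatic ring of carbon only, on this saturated chain carbon bound to an amide-type nitrogen and a carbonyl carbon. The earlier compounds shown here showed this only for methyl, isopropyl and 4-aminobutyl; the four compounds now show that a far larger side chain carrying an ester also leaves the numbers within the scatter of one another. No measurement at hand says why these numbers stay so close.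

As far as these compounds go, whether a free carboxylic acid in place of the benzyl ester at the end of this chain would give a similar number remains open. So does the outcome with a guanidine at the end of the chain.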